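Series notes: from compound 1 toward compound 4

A few compounds are considered here, and "the series" means these few. Any claim that something is new, unique, unknown or untested is made for them only; others in the source may bear on it.

Measured so far:
- compound 1 `C[C@@H](Cn1ccc(-c2ccc(C#N)c(Cl)c2)n1)NC(=O)c1ccccc1F`: 1810 nM
- compound 2 `CC(Cn1ccc(-c2ccc(C#N)c(Cl)c2)n1)C(=O)Nc1cccc(C(C)O)c1`: 4150 nM
- compound 3 `C[C@@H](Cn1ccc(-c2cc(F)c(C#N)c(Cl)c2)n1)NC(=O)Nc1cc(C(C)(C)C)[nH]n1`: 1630 nM

Three compounds of this series have been run in a functional assay on LNCaP cells (Homo sapiens) for antiproliferative activity, read by CCK-8 assay, with a stated time of 6 days; a lower number here means a stronger inhibitor, a higher number a weaker inhibitor. Compound 1 gives 1810 nM and stands second highest of the three numbers. Its nearest neighbour is compound 3 at 1630 nM, which lies within the scatter of compound 1. The furthest is compound 2 at 4150 nM, a higher number beyond the scatter. Because no two measured compounds differ in a single place, no shown step connects them, and nothing yet tells how the amide end of the molecule bears on the read-out.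

Compound 4 `C[C@@H](Cn1ccc(-c2ccc(C#N)c(Cl)c2)n1)Nc1ncccn1` is the next to be measured. For the measured compounds named here, it departs from compound 1 in one place: pyrimidin-2-yl in place of (2-fluorophenyl)carbonyl on an amine nitrogen No measured pair offers a precedent for this kind of change. Given the narrow spread among the three measured values, the step from compound 1 in this assay is expected to be modest, with no firm direction, and quite possibly no larger than the scatter. The expected step of a 1.4-fold higher number from compound 1 to compound 4 (0.14 log units; within the scatter) is accordingly small. Compound 4 is expected to give 2500 nM, within a range of 800 nM to 8000 nM.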

Compound 4, half-maximal inhibitory concentration: 1180 nM
For compound 4 the middle estimate is 2.1-fold (0.33 log units) above the measured one; low and high end bracket the measured number.
By their numbers in this assay, from the lowest: compounds 4, 3 and 1 (each within the scatter of the next); then compound 2.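

In this assay, for the compounds shown here, the only single-place step so far, a 1.5-fold lower number from compound 1 to compound 4 (0.19 log units; within the scatter), shows that the amine nitrogen can carry pyrimidin-2-yl in place of (2-fluorophenyl)carbonyl with the read-out staying within the scatter. At this position, then, the carbonyl is not needed to hold the number at this level, and a group of 6 heavy atoms serves as well here as one of 9. No measurement on hand explains this outcome.

The compounds shown leave open which part of the change matters, since loss of the carbonyl and the swap of the ring come together in this one step. A phenyl or a pyridin-2-yl on the same nitrogen would separate these two parts, and a pyrimidine-bearing analogue with a methyl group on the ring would test how much added bulk this position accepts.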